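Vinyl to Pent-1-en-1-yl on the Amide of Compound 3

A few compounds are considered here, and "the series" means these few. Any claim that something is new, unique, unknown or untested is made for them only; others in the source may bear on it.

Measured so far in a functional assay on A-431 cells (Homo sapiens) for inhibition, read by MTT assay, with a stated time of 72 h; on this read-out higher numbers stand for weaker inhibition and lower numbers for stronger inhibition:
compound 1, `C=CC(=O)Nc1cccc(Oc2nc(Nc3cccc(OC)c3)nc3ccsc23)c1`: 4790 nM
compound 2, `COc1ccc(Nc2nc(Oc3cccc(NC(=O)C=C(C)C)c3)c3sccc3n2)cn1`: > 50000 nM, a limit of the assay, not a number
compound 3, `C=CC(=O)Nc1cccc(Oc2nc(Nc3cccc(C#N)c3)nc3ccsc23)c1`: 3790 nM

Compound 3 holds the lowest of the two numbers, yet compound 1 sits within the scatter of it: a 1.3-fold lower number from compound 1 to compound 3 (0.10 log units; within the scatter). Compound 2 sits at the limit of > 50000 nM in this assay, at which 1 of the 3 values shown sits.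

Compound 4, `CCC/C=C/C(=O)Nc1cccc(Oc2nc(Nc3cccc(C#N)c3)nc3ccsc23)c1`, differs from compound 3 in one place: pent-1-en-1-yl in place of vinyl on a carbonyl carbon. Among the compounds with values here, no measured step changes this part of the molecule; the single step available, a 1.3-fold lower number from compound 1 to compound 3 (0.10 log units; within the scatter), alters a different group and stayed within the scatter, so it gives no guide here. Compound 2 carries both a different group on the carbonyl carbon and a different aromatic partner, so its limit cannot be tied to one change.

Compound 4 is therefore expected to give a higher number in this assay, estimated at 15000 nM, within 4000 nM to 50000 nM. The expected step is a 4.0-fold higher number from compound 3 to compound 4 (0.60 log units; beyond the scatter).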

Compound 4, half-maximal inhibitory concentration: 20400 nM
The estimate for compound 4 lay 1.4-fold (0.13 log units) below the measured number; the range from low to high includes it.
By their numbers in this assay, from the lowest: compounds 3 and 1 (each within the scatter of the next); then compound 4. At a limit, above all of these: compound 2.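

In this assay, within the data shown here, swapping vinyl for pent-1-en-1-yl on the carbonyl carbon gives a 5.4-fold higher number from compound 3 to compound 4 (0.73 log units; beyond the scatter), the first single change at this place and the first measured step beyond the scatter. The amide end of the molecule therefore affects this read-out, and the longer chain is tolerated less well than vinyl. Nothing shown here explains why the number rises.

Still open, on these data alone, is how a shorter chain such as prop-1-en-1-yl would behave at this place, and whether a dimethylamino group at the end of the chain would change the result.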